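The compounds below may be only part of what the source reports. "The series", "measured", "known", "first", "only" and "open" are said of these compounds alone.

Working notes on the series. Compound 1, `Cc1cc2[nH]nc(N)c2c(=O)[nH]1`, and compound 2, `CC(C)(C)c1cc2[nH]nc(N)c2c(=O)[nH]1`, share one core. In an assay on isolated protein for inhibition of MAP kinase-activated protein kinase 2 (Homo sapiens), read by mobility shift assay, tested at 30 uM (a higher number here means more inhibition at the concentration tested (going by the name of the read-out), a lower number less inhibition), compound 1 gives 30%, and compound 2 gives 39%. The step of a number 9 percentage points higher from compound 1 to compound 2 (within the scatter) comes from tert-butyl in place of methyl on an aromatic carbon.

Compound 3, `Cc1cc2nn(-c3ccccc3)c(N)c2c(=O)[nH]1`, is built on a second core; how that core differs from the core of compound 1 is not broken down here. In this assay compound 3 gives -4%, the lowest number of the three: compound 1 stands higher than compound 3 beyond the scatter, and compound 2 further beyond still.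

Compound 4, `CC(C)(C)c1cc2nn(-c3ccccc3)c(N)c2c(=O)[nH]1`, has not been measured yet. From compound 3 it differs by tert-butyl in place of methyl on an aromatic carbon, the same change that separates compound 1 from compound 2, at the same place. Because that earlier step, a number 9 percentage points higher from compound 1 to compound 2 (within the scatter), stayed within the scatter, the step expected for compound 4, a number 6 percentage points higher from compound 3 to compound 4 (within the scatter), is likewise expected to be small. Compound 4 is therefore estimated at about 2% in this assay, expected to fall between -12% and 16%.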

Compound 4, a percentage reported as inhibition, at one concentration (the size of the read-out at that concentration, not a potency): 6%
The estimate for compound 4 lay 4 percentage points below the measured number; the range from low to high includes it.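

In this assay, tert-butyl in place of methyl on an aromatic carbon gives a number 10 percentage points higher from compound 3 to compound 4 (within the scatter), and this step agrees with the one seen on the core of compound 1: the same change on two cores in this assay, a number 9 percentage points higher (within the scatter) from compound 1 to compound 2 and a number 10 percentage points higher (within the scatter) from compound 3 to compound 4, 1 percentage points apart, within the scatter of two such steps. On these two cores, then, the change carries over with no difference that can be detected, so the step on one core would have served as a fair guide to the step on the other. This does not show that the change itself has any effect on either core, since each step lies within the scatter, and two cores are too few to establish a rule for the series.

The compounds shown leave open how an amine, a carboxylic acid or a longer chain on this aromatic carbon would read in this assay, since only methyl and tert-butyl appear there. Also open, going by these compounds, is whether the agreement between the two steps would hold on a third core.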